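A few compounds are considered here, and "the series" means these few. Any claim that something is new, unique, unknown or untested is made for them only; others in the source may bear on it.

In a functional assay on HCT-116 cells (Homo sapiens) for antiproliferative activity, read by MTT assay, with a stated time of 72 h (a higher number here means a weaker inhibitor, a lower number a stronger inhibitor), compound 1 `O=C(O)c1ccc(OCCOc2ccc3cc2COC/C=C/COCc2cccc(c2)-c2ccnc(n2)N3)cc1` gives 29700 nM and compound 2 `O=C(O)CCCCCOc1ccc2cc1COC/C=C/COCc1cccc(c1)-c1ccnc(n1)N2` gives 41000 nM, so the two stand level within the scatter. Compound 3 `O=C(O)c1cccc(NCCOc2ccc3cc2COC/C=C/COCc2cccc(c2)-c2ccnc(n2)N3)c1` differs from compound 2 by (3-carboxyphenyl)amino in place of 3-carboxypropyl on a saturated chain carbon, two bonds along the chain from an oxygen on an aromatic ring, with (3-carboxyphenyl)amino in place of 3-carboxypropyl. Within the data shown here, only one measured step bears on this change: a 1.4-fold higher number from compound 1 to compound 2 (0.14 log units; within the scatter), where 3-carboxypropyl replaced 4-carboxyphenoxy at the same place. That step is small, so no change beyond the scatter is expected in this assay. The expected size is a 1.4-fold lower number from compound 2 to compound 3 (0.14 log units; within the scatter). Compound 3 is estimated at 30000 nM, with an expected range of 12000 nM to 70000 nM.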

Compound 3, half-maximal inhibitory concentration: 59200 nM
Compound 3: the middle estimate sits 2.0-fold (0.30 log units) below what was measured; low and high end bracket the measured number.
By their numbers in this assay, from the lowest: compounds 1, 2 and 3 (each within the scatter of the next).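

Putting (3-carboxyphenyl)amino in place of 3-carboxypropyl gives a 1.4-fold higher number from compound 2 to compound 3 (0.16 log units; within the scatter) in this assay, and putting it in place of 4-carboxyphenoxy gives a 2.0-fold higher number from compound 1 to compound 3 (0.30 log units; within the scatter) in the same assay. Among these compounds, this place on the chain therefore now holds three different carboxylic acid groups, with or without an aromatic ring and with an oxygen or nitrogen link, and no step goes beyond the scatter. Nothing available explains these numbers.

Going by these compounds, all three compounds carry a carboxylic acid, so a group without one, such as an amine or an amide, remains open. On these data alone, a simple alkyl chain at this place also remains open.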